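Microsomal stability across a cyclohexyl amide series

This account rests on a few compounds, and the source may have more. Where it says the series, first, only, none or still open, it means among the compounds named here.

Compound 1 `C[C@]1(C(=O)N2CC[C@](c3ccc(C(F)(C(F)(F)F)C(F)(F)F)cc3)(S(=O)(=O)c3ccc(F)cc3)C2)CC[C@H](C(=O)O)CC1` gives 95% in an ADME assay on microsomes from liver (Mus musculus) for metabolic stability, with a stated time of 10 min; on this read-out higher numbers stand for a more stable compound and lower numbers for a less stable compound. Compound 2 `CO[C@]1(C(=O)N2CC[C@](c3ccc(C(F)(C(F)(F)F)C(F)(F)F)cc3)(S(=O)(=O)c3ccc(F)cc3)C2)CC[C@H](C(=O)O)CC1` gives 95% in this assay, so compound 2 stands level with compound 1 at the digits shown; the step of no change at the digits printed from compound 1 to compound 2 (within the scatter) is the only one measured. Compound 3 `NC(=O)[C@H]1CC[C@H](C(=O)N2CC[C@](c3ccc(C(F)(C(F)(F)F)C(F)(F)F)cc3)(S(=O)(=O)c3ccc(F)cc3)C2)CC1` differs from compound 2 by 4-carbamoylcyclohexyl in place of 4-carboxy-1-methoxycyclohexyl on a carbonyl carbon. Among the compounds with values here, no measured step covers an exchange of this kind, and the one measured step, methoxy for methyl, was flat. For compound 3 the step of a number 7 percentage points lower from compound 2 to compound 3 (within the scatter) in this assay is therefore expected to be small, if any. Compound 3 is estimated at 88%, within 70% to 98%.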

Compound 3, percent of the compound remaining: 100%
Compound 3: the middle estimate sits 12 percentage points below what was measured; measured number above the stated range.
By their numbers in this assay, from the lowest: compounds 1, 2 and 3 (each within the scatter of the next).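

The exchange of the 4-carboxy-1-methoxycyclohexyl or 4-carboxy-1-methylcyclohexyl group for 4-carbamoylcyclohexyl on a carbonyl carbon gives a number 5 percentage points higher from compound 2 to compound 3 (within the scatter) and a number 5 percentage points higher from compound 1 to compound 3 (within the scatter) in this assay. At this place, a change of the whole substituent, not only the methoxy-for-methyl exchange, thus leaves the read-out within the scatter. Nothing available explains this flat result.

Still open, going by these compounds, is whether an amine or a nitrile in place of the carbamoyl group would give a step beyond the scatter. The three compounds shown do not yet mark any limit of change at this place.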